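Swapping a methoxybenzyl ether for a second oxadiazolone arm

A few compounds are considered here, and "the series" means these few. Any claim that something is new, unique, unknown or untested is made for them only; others in the source may bear on it.

Of the compounds shown here, three built on a long-chain ether scaffold have been measured in a physicochemical assay for lipophilicity; on this read-out higher numbers stand for higher lipophilicity and lower numbers for lower lipophilicity. Compound 1 `CCCCCCCCCCCCCCOC(COCc1cccc(OC)c1)COc1ccc(-c2noc(=O)[nH]2)cc1` gives 8.56. Compound 3 `CCCCCCCCCOCC(COc1ccc(Cc2noc(=O)[nH]2)cc1)OCCCCCCCCC` gives 9.18, and compound 2 `CCCCCCCCCCCCCCOC(COc1ccc(Cc2noc(=O)[nH]2)cc1)COc1ccc(Cc2noc(=O)[nH]2)cc1` gives 7.64. Among these three numbers compound 1 stands second highest: compound 3 lies above it and compound 2 below it, and both gaps are beyond the scatter of this assay.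

Compound 4 `CCCCCCCCCCCCCCOC(COc1ccc(-c2noc(=O)[nH]2)cc1)COc1ccc(-c2noc(=O)[nH]2)cc1` has not yet been measured. It differs from compound 1 in one place: a group of 12 heavy atoms (8 carbon, 2 nitrogen, 2 oxygen; one five-membered aromatic ring with 3 hetero atoms, one six-membered aromatic ring of carbon only) in place of a group of 9 heavy atoms (8 carbon, 1 oxygen; one six-membered aromatic ring of carbon only), on an oxygen on a saturated carbon. Compound 4 thus carries two of the same aryl-oxadiazolone groups at the two ends of the shared core, much as compound 2 carries two benzyl-oxadiazolone groups.

Within the data shown here, no directly comparable step between measured compounds exists here. Among the measured compounds shown here, still, the group that enters brings a hydrogen-bond donor and more acceptors than the group that leaves, and compound 2, the only other compound with two oxadiazolone arms, gives the lowest of the measured values. A downward step of a number 0.96 log units lower from compound 1 to compound 4 (beyond the scatter) is therefore expected. Compound 4 is estimated to give 7.6 in this assay, with a likely range from 7 to 8.2.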

Compound 4, partition coefficient: 7.05
Compound 4: the middle estimate sits 0.55 log units above what was measured, within the range that was stated.
By their numbers in this assay, from the lowest: compound 4; then compound 2; then compound 1; then compound 3.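

In this assay, among these compounds, placing the aryl-oxadiazolone group on an oxygen on a saturated carbon, where compound 1 carries 3-methoxybenzyl, gives a number 1.51 log units lower from compound 1 to compound 4 (beyond the scatter), the only step here in which a single place changes and the rest of the molecule stays the same. It shows that this read-out responds strongly to what sits at this position, even though the long chain of the shared core stays in place. The entering group has more heavy atoms than the leaving group and a hydrogen-bond donor that the leaving group lacks, so in this pair the larger group gives the lower number, and nothing measured shows which of its features accounts for the step.

Still open, going by these compounds, is how much of the step belongs to the oxadiazolone ring itself, a question that a carboxylic acid or an amide on the same six-membered aromatic ring could help to answer. Also open, on these data alone, is whether a step of this size would recur on the same core with a shorter chain, such as an octyl chain, in place of the long one.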